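Semicarbazide series: cytotoxicity notes toward compound 4

A few compounds are considered here, and "the series" means these few. Any claim that something is new, unique, unknown or untested is made for them only; others in the source may bear on it.

Measured so far:
compound 1 `COc1cc(NC(C)CCCNC(=O)NNC(=O)/C(C)=C/c2ccccc2)c2ncccc2c1`: 36500 nM
compound 2 `COc1cc(NC(C)CCCNC(=O)NNC(=O)/C=C/c2ccc(Cl)cc2)c2ncccc2c1`: 7300 nM
compound 3 `COc1cc(NC(C)CCCNC(=O)NNC(=O)NC(CO)(CO)CO)c2ncccc2c1`: "not determined" (no result reported)

For the measured compounds named here, in an ADME assay on L6 cells (Rattus norvegicus) for cytotoxicity, read by resazurin assay, with a stated time of 70 h (a lower number here means a stronger inhibitor, a higher number a weaker inhibitor), compound 1 gives 36500 nM and compound 2 gives 7300 nM; the only measured step, a 5.0-fold lower number from compound 1 to compound 2 (0.70 log units; beyond the scatter), concerns the acyl end of the chain. Compound 3 has no single number here: for compound 3 the result stands as "not determined" (no result reported). Going by the values given here, compound 4 `COc1cc(NC(C)CCCNC(=O)NNC(=O)Nc2ccc(Br)cc2)c2ncccc2c1` differs from it at the terminal amide-type nitrogen. 4-bromophenyl in place of 2-hydroxy-1,1-bis(hydroxymethyl)ethyl on an amide-type nitrogen No measured step bears on this change, as nothing measured varies the group on that nitrogen, and compound 3 offers no anchor. The expectation therefore rests on the span of the two measured compounds in this assay alone, with no direction claimed. Compound 4 is estimated at 12000 nM, within 3000 nM to 50000 nM.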

Compound 4, half-maximal inhibitory concentration: 38700 nM
Compound 4: the middle estimate sits 3.2-fold (0.51 log units) below what was measured; low and high end bracket the measured number.
By their numbers in this assay, from the lowest: compound 2; then compounds 1 and 4 (each within the scatter of the next).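

For the compounds shown here, the step of a 1.1-fold higher number from compound 1 to compound 4 (0.03 log units; within the scatter) in this assay gives a first reading for a (4-bromophenyl)amino end on the carbonyl carbon, and it does not separate that end from the 1-methyl-2-phenylethenyl end. By contrast, the step of a 5.3-fold higher number from compound 2 to compound 4 (0.72 log units; beyond the scatter) separates it from the 2-(4-chlorophenyl)ethenyl end. The change from compound 3 to compound 4 itself cannot be read, and nothing available explains either step.

Open, going by these compounds, is whether the bromine counts here, as against a plain phenyl or 4-chlorophenyl on that nitrogen. Also open, on these data alone, is how a methyl or a longer alkyl chain there would read.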